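Chloro for Trifluoromethyl on the Benzyl Ether: Compound 4

A few compounds are considered here, and "the series" means these few. Any claim that something is new, unique, unknown or untested is made for them only; others in the source may bear on it.

Three compounds were measured in a functional assay on HT-29 cells (Homo sapiens) for inhibition, read by MTT assay, with a stated time of 48 h; on this read-out lower numbers stand for stronger inhibition and higher numbers for weaker inhibition:
compound 1 `Cc1ccc(NC(=O)NC(=O)c2ccc(OCc3cccc(Cl)c3)cc2)cc1-c1nc2ccccc2[nH]1` gives 15400 nM;
compound 2 `Cc1ccc(NC(=O)NC(=O)c2ccc(OCc3ccc(C(F)(F)F)cc3)cc2)cc1-c1nc2ccccc2[nH]1` gives 7830 nM;
compound 3 `Cc1ccc(NC(=O)NC(=O)c2ccc(OCc3cccc(C(F)(F)F)c3)cc2)cc1-c1nc2ccccc2[nH]1` gives 3520 nM.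

Compound 3 has the lowest number of the three, separated from its nearest neighbour by a 2.2-fold lower number from compound 2 to compound 3 (0.35 log units; beyond the scatter) and from the furthest by a 4.4-fold lower number from compound 1 to compound 3 (0.64 log units; beyond the scatter). Compound 4 `Cc1ccc(NC(=O)NC(=O)c2ccc(OCc3cccc(Cl)c3Cl)cc2)cc1-c1nc2ccccc2[nH]1` differs from compound 3 in one place: 2,3-dichlorophenyl in place of 3-(trifluoromethyl)phenyl on a saturated chain carbon bound to an oxygen on an aromatic ring. Going by the values given here, the step that bears on this change is the one from compound 1 to compound 3, in which trifluoromethyl replacing chloro on the same aromatic carbon gave a modest improvement; the added chloro of compound 4 has no measured counterpart. A modest move back toward compound 1 is therefore expected, a 2.3-fold higher number from compound 3 to compound 4 (0.36 log units; beyond the scatter). Compound 4 is estimated at 8000 nM, with a range from 2500 nM to 25000 nM.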

Compound 4, half-maximal inhibitory concentration: 48500 nM
Beside the measured number, compound 4's estimate is 6.1-fold (0.78 log units) below it; measured number above the stated range.
By their numbers in this assay, from the lowest: compound 3; then compounds 2 and 1 (each within the scatter of the next); then compound 4.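

In this assay the added chloro gives a 3.1-fold higher number from compound 1 to compound 4 (0.50 log units; beyond the scatter) and shows that this ring does not tolerate every further substituent. Compound 4 also falls behind both trifluoromethyl compounds, with a 6.2-fold higher number from compound 2 to compound 4 (0.79 log units; beyond the scatter) and the large 14-fold higher number from compound 3 to compound 4 (1.14 log units; beyond the scatter) as the steps, so the 2,3-dichlorophenyl group ranks last of the four at this place. No measurement offers a reason for this loss. As far as these compounds go, whether the loss depends on where the added chloro sits remains open. So does how a methoxy group or an amine on this ring would compare.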